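Compound 1 and the dichlorophenyl swap

The source may report more compounds than this note shows. Statements on the series, on what has been measured and on what is new or still open speak of the compounds shown alone.

Measured so far in a functional assay on SR cells (Homo sapiens) for inhibition, read by sulforhodamine B assay, with a stated time of 48 h; on this read-out higher numbers stand for weaker inhibition of growth and lower numbers for stronger inhibition of growth
compound 1 `O=C(Nc1cccc(-n2cc(-c3ccncc3)c(-c3ccc(Cl)c(O)c3)n2)c1)Nc1cccc(C(F)(F)F)c1` gives 1820 nM
compound 2 `COc1cc(-c2nn(-c3cccc(NC(=O)Nc4cc(C(F)(F)F)cc(C(F)(F)F)c4)c3)cc2-c2ccncc2)ccc1Cl` gives 1080 nM
compound 3 `COc1cc(-c2nn(-c3cccc(NC(=O)Nc4ccc(Cl)c(Cl)c4)c3)cc2-c2ccncc2)ccc1Cl` gives 932 nM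

These three values lie within the usual scatter of one another, so compound 1 stands level with compound 2 and compound 3 on these numbers. Compound 4 `O=C(Nc1cccc(-n2cc(-c3ccncc3)c(-c3ccc(Cl)c(O)c3)n2)c1)Nc1ccc(Cl)c(Cl)c1` has not yet been measured. It keeps the core of compound 1, and the change is 3,4-dichlorophenyl in place of 3-(trifluoromethyl)phenyl on an amide-type nitrogen which puts 3,4-dichlorophenyl in place of 3-(trifluoromethyl)phenyl on an amide-type nitrogen. Within the data shown here, no pair of measured compounds shows this change alone, so the data offer no direct step. Compound 3 also carries 3,4-dichlorophenyl and gives 932 nM in this assay and this lies within the scatter of compound 1 at 1820 nM in the same test. On that basis, no step beyond the scatter is expected. The expected step is a 1.4-fold lower number from compound 1 to compound 4 (0.15 log units; within the scatter) and it is estimated to stay within the scatter. Compound 4 is expected at 1300 nM within a range from 650 nM to 2500 nM on this estimate.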

Compound 4, concentration for 50% growth inhibition: 1140 nM
Estimate against measurement, compound 4: 1.1-fold (0.06 log units) above; the range from low to high includes it.
By their numbers in this assay, from the lowest: compounds 3, 2, 4 and 1 (each within the scatter of the next).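

Among these compounds, on the amide-type nitrogen, the earlier compounds offered no direct step; in this assay, 3,4-dichlorophenyl in place of 3-(trifluoromethyl)phenyl now gives a 1.6-fold lower number from compound 1 to compound 4 (0.20 log units; within the scatter), which stays within the scatter, so these two rings cannot be told apart at this position. The second pair adds a separate reading on the other side of the molecule: hydrogen in place of methyl on an oxygen on an aromatic ring gives a 1.2-fold higher number from compound 3 to compound 4 (0.09 log units; within the scatter), also within the scatter, with the 3,4-dichlorophenyl group held in both compounds. No evidence is at hand that bears on these readings.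

On these data alone, both rings at this nitrogen are chlorine- or fluorine-bearing phenyl groups, so it remains open whether this position responds to anything else. A cyclohexyl ring, a pyridine ring or a phenyl ring carrying an amine or a carboxylic acid is not among the compounds shown.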